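The source may report more compounds than this note shows. Statements on the series, on what has been measured and on what is new or still open speak of the compounds shown alone.

Measured compounds:
compound 1 `CCN(CC)c1ccc2cc(C(=O)c3ccc(N4CCN(C(=O)CN5CCN(C(=O)/C=C/c6ccccc6)CC5)CC4)cc3)oc2c1`: 5260 nM
compound 2 `CCN(CC)c1ccc2cc(C(=O)c3ccc(N4CCN(C(=O)CN5CCN(S(=O)(=O)c6ccc(OC(F)(F)F)cc6)CC5)CC4)cc3)oc2c1`: 30200 nM

Two compounds have been run in a functional assay on HeLa cells (Homo sapiens) for cytotoxicity, read by MTT assay, with a stated time of 48 h; on this read-out lower numbers stand for stronger inhibition and higher numbers for weaker inhibition. Compound 1 gives 5260 nM in this assay, the lower of the two numbers. Compound 2 gives 30200 nM in this assay, a higher number, and the gap between these two values lies beyond the usual scatter, so compound 1 stands as the more active of the pair. Within the data shown here, no direct step between them has been worked out.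

Compound 3 `C#CCN1CCN(CC(=O)N2CCN(c3ccc(C(=O)c4cc5ccc(N(CC)CC)cc5o4)cc3)CC2)CC1` is not yet measured. It differs from compound 1 by a single change: propargyl in place of (2-phenylethenyl)carbonyl on an amine nitrogen in a ring. The shared core and the rest of the chain are kept.

Among the measured compounds shown here, with no measured pair that isolates such a change, the size of the step is open. For the measured compounds named here, the only guide is that the one other variation at this position, in compound 2, gave a higher number. A modest shift toward weaker inhibition is expected rather than a gain: the step from compound 1 to compound 3 is estimated as a 1.9-fold higher number from compound 1 to compound 3 (0.28 log units; within the scatter). Compound 3 is expected to give about 10000 nM in this assay, within a range of 3000 nM to 40000 nM.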

Compound 3, half-maximal inhibitory concentration: > 40000 nM
Compound 3 gave a limit, no number (the forecaster's own chance of this, stated with the estimate: 10%); middle value at least 4.0-fold (0.60 log units) from the limit.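

In this assay compound 3 gives > 40000 nM, which is a limit of the assay and not a number. This gives the series its first listed step at the amine nitrogen in the ring: replacing (2-phenylethenyl)carbonyl with propargyl produces an at least 7.6-fold higher number from compound 1 to compound 3 (0.88 log units; beyond the scatter), so a single change at this position can move the read-out beyond the scatter, toward weaker inhibition. The true size of that step remains unresolved, and the reading rests on one censored value: the limit of > 40000 nM in this assay, at which 1 of the 3 values shown sits.

The change removes a six-membered aromatic ring of carbon only and a carbonyl together, so these compounds cannot show which part of the group in compound 1 accounts for the difference. A benzyl group, which keeps an aromatic ring without the carbonyl, and an acetyl group, which keeps the carbonyl without the ring, would separate these two features on this nitrogen.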